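The source may report more compounds than this note shows. Statements on the series, on what has been measured and on what is new or still open speak of the compounds shown alone.

Compound 1 `COc1ccnc(NC[C@@H]2C[C@@H](OCC(=O)NC[C@H](NC(=O)C3(C)CCCCC3)C(=O)O)CN2C(=O)OCc2ccccc2)c1` gives 0.8 nM in an assay on a protein complex for inhibition of integrin alpha-5/beta-1 (Homo sapiens), read by ELISA; a higher number here means a weaker inhibitor, a lower number a stronger inhibitor.
Compound 2 `COc1ccnc(NC[C@@H]2C[C@@H](OCC(=O)NC[C@H](NS(=O)(=O)c3c(C)cc(C)cc3C)C(=O)O)CN2C(=O)OCc2ccccc2)c1` gives 1.1 nM in this assay.
Compound 3 `Cc1cc(C)c(S(=O)(=O)N[C@@H](CNC(=O)CO[C@@H]2C[C@@H](CNc3ccccn3)N(C(=O)CC(C)(C)C)C2)C(=O)O)c(C)c1` gives 6 nM in this assay.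

Compounds 1 and 2 share one core and differ in a single place: (1-methylcyclohexyl)carbonyl in place of (2,4,6-trimethylphenyl)sulfonyl on an amine nitrogen. That change made a 1.4-fold lower number from compound 2 to compound 1 (0.14 log units; within the scatter), so the two compounds cannot be told apart by their numbers. Compound 3 is built on a different core; the difference between the two cores is not broken down here. Its number is the highest of the three, and its gap to compound 2 and to compound 1 lies beyond the scatter.

Compound 4 `CC(C)(C)CC(=O)N1C[C@H](OCC(=O)NC[C@H](NC(=O)C2(C)CCCCC2)C(=O)O)C[C@H]1CNc1ccccn1` has not yet been measured. It differs from compound 3 in exactly the way compound 1 differs from compound 2: (1-methylcyclohexyl)carbonyl in place of (2,4,6-trimethylphenyl)sulfonyl on an amine nitrogen. The surroundings of the place are the same, so this is the same change. Because the earlier instance gave a 1.4-fold lower number from compound 2 to compound 1 (0.14 log units; within the scatter), the step is expected to be similarly small, about a 1.3-fold lower number from compound 3 to compound 4 (0.12 log units; within the scatter). Compound 4 is therefore expected to give 4.5 nM, with a range from 2 nM to 12 nM, in this assay.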

Compound 4, half-maximal inhibitory concentration: 1.4 nM
The estimate for compound 4 lay 3.2-fold (0.51 log units) above the measured number; the whole stated range lies above it.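

On the core of compound 3, putting (1-methylcyclohexyl)carbonyl in place of (2,4,6-trimethylphenyl)sulfonyl on an amine nitrogen gave a 4.3-fold lower number from compound 3 to compound 4 (0.63 log units; beyond the scatter) in this assay. The same change therefore did not carry the same size of step from one core to the other: the same change on two cores in this assay, a 1.4-fold lower number (0.14 log units; within the scatter) from compound 2 to compound 1 and a 4.3-fold lower number (0.63 log units; beyond the scatter) from compound 3 to compound 4, 3.1-fold (0.49 log units) apart, beyond the scatter of two such steps. This shows that, in this series, a step measured on one core can be a poor guide to its size on another, but two pairs of compounds do not show which difference between the cores matters, or how the change would behave on a further core.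

As far as these compounds go, only these two groups appear on that amine nitrogen, so it remains open whether a simple acetyl or an unsubstituted benzenesulfonyl group would also give steps of different size on the two cores. Going by these compounds alone, a pair of compounds differing in only one part of the core would be needed to show which part alters the size of the step.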